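Replacing the 3-fluorophenyl Group of Compound 2

A few compounds are considered here, and "the series" means these few. Any claim that something is new, unique, unknown or untested is made for them only; others in the source may bear on it.

Measured in a functional assay on U-937 cells (Homo sapiens) for antiproliferative activity, read by MTT assay, with a stated time of 24 h; on this read-out higher numbers stand for weaker inhibition and lower numbers for stronger inhibition:
- compound 1 `CNC(=O)c1ccccc1Oc1nc(Nc2cccc(OC)c2)ncc1Br`: 24300 nM
- compound 2 `Cc1cccc(Nc2ncc(Br)c(Oc3cccc(F)c3)n2)c1`: 19400 nM
- compound 3 `Cc1cccc(Nc2ncc(Br)c(Oc3cccc([N+](=O)[O-])c3)n2)c1`: 51200 nM

Compound 2 has the lowest number of the three, but compound 1 lies within the usual scatter of it, so the two cannot be ranked. Only compound 3 stands clearly apart.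

The next compound, compound 4 `Cc1cccc(Nc2ncc(Br)c(Oc3ccc(Br)cc3)n2)c1`, has not yet been measured. It carries 4-bromophenyl in place of 3-fluorophenyl on an oxygen on an aromatic ring.

Within the data shown here, one measured step bears on this change: a 2.6-fold higher number from compound 2 to compound 3 (0.42 log units; beyond the scatter). It puts nitro in place of fluoro on an aromatic carbon, and it is modest in size. Among the measured compounds shown here, no measured compound carries a 4-bromophenyl group, so that step is only a rough guide to size and gives no direction for this change. The expected change in this assay is a 1.1-fold higher number from compound 2 to compound 4 (0.03 log units; within the scatter), which means none beyond the scatter. For compound 4 the estimated value is 21000 nM, with an expected range from 8500 nM to 52000 nM.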

Compound 4, half-maximal inhibitory concentration: 18600 nM
Compound 4: middle estimate off by 1.1-fold (0.05 log units), on the high side; the range from low to high includes it.
By their numbers in this assay, from the lowest: compounds 4, 2 and 1 (each within the scatter of the next); then compound 3.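

In this assay, 4-bromophenyl in place of 3-fluorophenyl on the oxygen gives a 1.0-fold lower number from compound 2 to compound 4 (0.02 log units; within the scatter), so compound 2 and compound 4 cannot be told apart. Before this result, the only measured step at this part of the molecule was the swap of fluoro for nitro, a 2.6-fold higher number from compound 2 to compound 3 (0.42 log units; beyond the scatter), which did reach beyond the scatter; this new step shows that not every change on this ring does so. Nothing measured here explains why the two halogen-bearing rings give such similar numbers.

From the compounds shown here alone, the halogen and its number on the ring changed together in this step, so the effect of each alone remains unknown, and two opposite effects cannot be ruled out. Going by these compounds, how an amine or a carboxylic acid on this ring would compare also stays open.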